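The compounds below may be only part of what the source reports. "The series", "measured", "known", "first", "only" and "open" are said of these compounds alone.

In a functional assay on PC-3 cells (Homo sapiens) for antiproliferative activity, read by MTT assay, with a stated time of 72 h (a higher number here means a weaker inhibitor, a lower number a stronger inhibitor), compound 2 `O=C(N/N=C/c1ccc(F)cc1)Nc1ccc(Oc2ccnc3[nH]ccc23)c(F)c1` gives 2330 nM and compound 1 `O=C(N/N=C/c1cccc(Br)c1)Nc1ccc(Oc2ccnc3[nH]ccc23)c(F)c1` gives 4020 nM, so the two cannot be told apart. Compound 3 `O=C(N/N=C/c1cccc([N+](=O)[O-])c1)Nc1ccc(Oc2ccnc3[nH]ccc23)c(F)c1` has 3-nitrophenyl in place of 4-fluorophenyl on a carbon with a double bond to nitrogen. Within the data shown here, the only measured step at this place, a 1.7-fold lower number from compound 1 to compound 2 (0.24 log units; within the scatter), stayed within the scatter, so no clear step beyond the scatter is expected in this assay, in either direction. For compound 3 the estimated value is 2800 nM, with an expected range of 900 nM to 8000 nM. The expected change is a 1.2-fold higher number from compound 2 to compound 3 (0.08 log units; within the scatter).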

Compound 3, half-maximal inhibitory concentration: 5140 nM
Compound 3: middle estimate off by 1.8-fold (0.26 log units), on the low side; the measured number falls inside the stated range.
By their numbers in this assay, from the lowest: compounds 2, 1 and 3 (each within the scatter of the next, the first and the last beyond it).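

In this assay, this position gives its first step beyond the scatter, though a modest one: a 2.2-fold higher number from compound 2 to compound 3 (0.34 log units; beyond the scatter). The step with the substituent's location unchanged stays within the scatter, a 1.3-fold higher number from compound 1 to compound 3 (0.11 log units; within the scatter), so among these compounds the two groups at that location cannot be told apart. No measured finding explains either step.

Still open, as far as these compounds go, is whether the larger step follows the substituent itself or its location, as 4-fluorophenyl and 3-nitrophenyl differ in both. From the compounds shown here alone, how an amine or a carboxylic acid on this phenyl ring would read also remains unknown.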